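Methoxy for Methyl at the Assay Limit

This account rests on a few compounds, and the source may have more. Where it says the series, first, only, none or still open, it means among the compounds named here.

In a functional assay on DU-145 cells (Homo sapiens) for antiproliferative activity, read by MTT assay, with a stated time of 72 h (on this read-out higher numbers stand for weaker inhibition and lower numbers for stronger inhibition), compound 1 (`Cc1ccc(N(C)S(=O)(=O)C2CC3OC2C(c2ccc(NC(=O)CCCCCCC(=O)O)cc2)=C3c2ccc(O)cc2)cc1`) gives > 100000 nM, which is a limit and not a number. Compound 2 (`Cc1cccc(N(C)S(=O)(=O)C2CC3OC2C(c2ccc(NC(=O)CCCCCCC(=O)O)cc2)=C3c2ccc(O)cc2)c1`) gives > 100000 nM, which is also a limit, so it has no measured potency to rank. For the measured compounds named here, the only measured step is a step that the two limits leave unreadable from compound 1 to compound 2, and it has no readable size. Both compounds stand at the limit of > 100000 nM in this assay, at which 2 of the 2 values shown sit.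

Compound 3 (`COc1cccc(N(C)S(=O)(=O)C2CC3OC2C(c2ccc(NC(=O)CCCCCCC(=O)O)cc2)=C3c2ccc(O)cc2)c1`) differs from compound 2 by methoxy in place of methyl on an aromatic carbon, with methoxy in place of methyl on an aromatic carbon, meta to a large group. The methyl shift in a step that the two limits leave unreadable from compound 1 to compound 2 brought no measurable activity into view, so compound 3 is expected to stay at or near the limit in this assay, with no change beyond the scatter. The expected step is a number no higher from compound 2 to compound 3 (the limit leaves the size open). For compound 3 the estimate is 100000 nM, with an expected range of 40000 nM to 200000 nM.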

Compound 3, half-maximal inhibitory concentration: 62200 nM
Estimate against measurement, compound 3: 1.6-fold (0.21 log units) above; low and high end bracket the measured number.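

Compound 3 is the only one of the three compounds that gives a number and not a limit: the limit of > 100000 nM in this assay, at which 2 of the 3 values shown sit.

In this assay, the change from 3-methylphenyl to 3-methoxyphenyl gives an at least 1.6-fold lower number from compound 2 to compound 3 (0.20 log units; that floor lies within the scatter), and replacing 4-methylphenyl with 3-methoxyphenyl gives an at least 1.6-fold lower number from compound 1 to compound 3 (0.20 log units; that floor lies within the scatter). Each of these steps is only a floor, so this position can yield a readable value, but neither step establishes a gain beyond the scatter.

The compounds shown leave open how far compound 1 and compound 2 actually lie from compound 3, and whether methoxy has any real advantage over methyl at this place. They also leave open what an amine, a carboxylic acid or a longer chain in place of methoxy on this aromatic carbon would give in this assay.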